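From furan-2-yl to 3-methoxyphenyl: the half-life of compound 4

The compounds below may be only part of what the source reports. "The series", "measured", "known", "first", "only" and "open" are said of these compounds alone.

In a physicochemical assay for pharmacokinetics, read by fluorescence and HPLC, with a stated time of 24 h (on this read-out lower numbers stand for a shorter-lived compound and higher numbers for a longer-lived compound), compound 1 (`CC(C)(C)C1=C(C(=O)O)N2C(=O)/C(=C/c3ccco3)C2O1`) gives 0.22 h and stands level with its two measured relatives. Compound 2 (`CC(C)(C)C1=C(C(=O)O)N2C(=O)/C(=C/c3ccccc3)C2O1`) gives 0.21 h and compound 3 (`CC(C)(C)C1=C(C(=O)O)N2C(=O)/C(=C\c3ccoc3)C2O1`) gives 0.38 h and all three numbers lie within the scatter of one another. Compound 4 (`COc1cccc(/C=C2/C(=O)N3C(C(=O)O)=C(C(C)(C)C)OC23)c1`) has not yet been measured. Its difference from compound 1 (3-methoxyphenyl in place of furan-2-yl on a double-bonded chain carbon bound to a double-bonded ring carbon) is 3-methoxyphenyl in place of furan-2-yl on a double-bonded chain carbon bound to a double-bonded ring carbon. Going by the values given here, one measured step bears on this change: phenyl in place of furan-2-yl at that same place gives a 1.0-fold lower number from compound 1 to compound 2 (0.02 log units; within the scatter) and so shows no change beyond the scatter. Among the compounds with values here, no measured compound carries 3-methoxyphenyl, so that step is only a partial guide. The expected step is no change at the digits printed from compound 1 to compound 4 (within the scatter) and nothing beyond the scatter is expected in either direction. In this assay the estimate for compound 4 is 0.22 h (expected range 0.12 h to 0.4 h).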

Compound 4, half-life: 0.21 h
Beside the measured number, compound 4's estimate is 1.0-fold (0.02 log units) above it; the measured number falls inside the stated range.
By their numbers in this assay, from the lowest: compounds 2, 4, 1 and 3 (each within the scatter of the next).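

In this assay the step of a 1.0-fold lower number from compound 1 to compound 4 (0.02 log units; within the scatter) stays within the scatter, so a six-membered aromatic ring of carbon only that also carries a methoxy group, with more heavy atoms than furan-2-yl, leaves the half-life level at this place on a double-bonded chain carbon bound to a double-bonded ring carbon. The earlier compounds shown here showed this only for phenyl, whereas the step of no change at the digits printed from compound 2 to compound 4 (within the scatter) now adds that methoxy in place of hydrogen on an aromatic carbon also shows no change within the scatter. Nothing measured here accounts for this flat read-out.

Every compound shown keeps an aromatic ring at this place, so it stays open whether an amine or a carboxylic acid on that ring, or a longer alkyl chain in its stead, would move the half-life beyond the scatter. One methoxy group on one aromatic carbon also cannot say how the same group would behave elsewhere on the ring.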